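Tellurium in Place of Selenium Gives the Only Readable Number

The source may report more compounds than this note shows. Statements on the series, on what has been measured and on what is new or still open speak of the compounds shown alone.

Of the compounds shown here, three of one series have been tested in a functional assay on A-431 cells (Homo sapiens) for cytotoxicity, read by MTT assay, with a stated time of 24 h; on this read-out lower numbers stand for stronger inhibition and higher numbers for weaker inhibition. Compound 1 `COc1ccc(N(CC(=O)NCCC[Se]c2ccccc2)C(=O)c2ccccc2)cc1` carries a selenium-bearing side chain and a benzoyl group on the amide-type nitrogen. Compound 2 `COc1ccc(N(CC(=O)NCCC[Se]c2ccccc2)C(=O)/C=C/c2ccccc2)cc1` differs from it by 2-phenylethenyl in place of phenyl on a carbonyl carbon. Compound 3 `COc1ccc(N(CC(=O)NCCC[Te]c2ccccc2)C(=O)c2ccccc2)cc1` differs from compound 1 by a group of 7 heavy atoms (6 carbon, 1 tellurium; one six-membered aromatic ring of carbon only) in place of a group of 7 heavy atoms (6 carbon, 1 selenium; one six-membered aromatic ring of carbon only), on a saturated chain carbon, three bonds along the chain from an amide-type nitrogen.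

In this assay compound 1 gives >= 100000 nM, which is a limit of the assay rather than a number. In this assay compound 2 likewise gives >= 100000 nM, again a limit. The step that the two limits leave unreadable from compound 1 to compound 2 therefore cannot be sized, due to the limit of >= 100000 nM in this assay, at which 2 of the 3 values shown sit. In this assay, for the measured compounds named here, compound 3 gives 5000 nM, the only number among the three; the step of an at least 20-fold lower number from compound 1 to compound 3 (1.30 log units; beyond the scatter) is the one clear result so far.

Compound 4 `COc1ccc(N(CC(=O)NCCC[Te]c2ccccc2)C(=O)/C=C/c2ccccc2)cc1` has not yet been measured. It differs from compound 3 by 2-phenylethenyl in place of phenyl on a carbonyl carbon, the same change that separates compound 2 from compound 1, made here on the core of compound 3 rather than that of compound 1. That earlier step is unreadable, so it carries no information about direction or size. The author expects the step of no change at the digits printed from compound 3 to compound 4 (within the scatter), resting only on compound 3 at 5000 nM. The two limits of compound 1 and compound 2 leave the change unsized and add nothing to this expectation. Compound 4 is therefore estimated at 5000 nM in this assay, with a likely range from 1500 nM to 30000 nM.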

Compound 4, half-maximal inhibitory concentration: 6000 nM
Compound 4: the middle estimate sits 1.2-fold (0.08 log units) below what was measured, and the stated range covers the measured number.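

In this assay the change of 2-phenylethenyl for phenyl on a carbonyl carbon, carried onto the tellurium core, gives a 1.2-fold higher number from compound 3 to compound 4 (0.08 log units; within the scatter), while the same change on the selenium core cannot be read, so this series offers no sized comparison of that change across the two cores. The change of selenium to tellurium, carried in turn onto the core bearing 2-phenylethenyl, gives an at least 16-fold lower number from compound 2 to compound 4 (1.22 log units; beyond the scatter), which points the same way as the earlier step on the core of compound 1, though this agreement in direction does not settle whether the two sizes match: the same change on two cores in this assay, an at least 20-fold lower number (1.30 log units; beyond the scatter) from compound 1 to compound 3 and an at least 16-fold lower number (1.22 log units; beyond the scatter) from compound 2 to compound 4; the limit leaves it open whether they differ Neither tellurium step has an exact size, and how far tellurium lowers the number on either core stays unknown, since each selenium partner is held at a limit of the assay rather than a number: the limit of >= 100000 nM in this assay, at which 2 of the 4 values shown sit.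

The compounds shown leave open whether the tellurium step would hold with an amine or a carboxylic acid on the benzoyl ring in place of the unsubstituted phenyl. They also leave open how a longer chain in place of the saturated chain carrying the tellurium would read in this assay.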